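This account rests on a few compounds, and the source may have more. Where it says the series, first, only, none or still open, it means among the compounds named here.

Measured values in a functional assay on A549 cells (Homo sapiens) for cytotoxicity, read by MTT assay, with a stated time of 48 h; a lower number here means a stronger inhibitor, a higher number a weaker inhibitor:
Compound 1 `Cc1nnc(SCc2ccccc2Cl)n1N1C(=O)c2ccccc2C1=O` gives > 200000 nM, a limit of the assay.
Compound 2 `CCCc1nnc(SCc2ccccc2Cl)n1N1C(=O)c2ccccc2C1=O` gives > 200000 nM, a limit of the assay.
Compound 3 `C=CCSc1nnc(-c2cc(OC)c(OC)c(OC)c2)n1N1C(=O)c2ccccc2C1=O` gives > 200000 nM, a limit of the assay.

Compound 3 therefore stands only at a limit: no number is known for it, and every measured value in this assay sits at the same limit, (the limit of > 200000 nM in this assay, at which 3 of the 3 values shown sit). Among the measured compounds shown here, the single measured step, a step that the two limits leave unreadable from compound 1 to compound 2, runs between two limits and cannot be read in size or direction; it also concerns a different change than the one at hand.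

The unmeasured compound 4 `COc1cc(-c2nnc(SCc3ccccc3Cl)n2N2C(=O)c3ccccc3C2=O)cc(OC)c1OC` differs from compound 3 in one place: 2-chlorophenyl in place of vinyl on a saturated chain carbon bound to a sulfur. For the measured compounds named here, no measured step bears on this exchange. Because the limit of > 200000 nM in this assay, at which 3 of the 3 values shown sit, holds for all three measured compounds, compound 4 is expected to remain at or beyond that limit in this assay. Compound 4 is estimated at 300000 nM, with a range from 100000 nM to 1000000 nM. The expected step implied by this estimate, a step that the limit leaves unreadable from compound 3 to compound 4, is none beyond the scatter, and most likely the assay again reports only a limit.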

Compound 4, half-maximal inhibitory concentration: > 200000 nM
Compound 4: only a limit was reported (the forecaster's own chance of this, stated with the estimate: 80%); the middle value does not contradict the limit.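

In this assay compound 4 gives > 200000 nM, a limit of the assay and not a number. Among the compounds shown here, no step from compound 1, compound 2 or compound 3 to compound 4 can be read, in size or in direction. The compounds shown leave open which change on the shared core, if any, would give a readable number in this assay: the limit of > 200000 nM in this assay, at which 4 of the 4 values shown sit.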